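Ethoxy for chloro on the fused ring of compound 3

A few compounds are considered here, and "the series" means these few. Any claim that something is new, unique, unknown or untested is made for them only; others in the source may bear on it.

Measured compounds in a functional assay on MV4-11 cells (Homo sapiens) for cytotoxicity, read by MTT assay, with a stated time of 72 h; on this read-out lower numbers stand for stronger inhibition and higher numbers for weaker inhibition:
- compound 1 `CC(C)(C)c1cc(NC(=O)Nc2ccc(-c3cn4ccncc4n3)cc2)no1` gives 44.8 nM
- compound 2 `CC(C)(C)c1cc(NC(=O)Nc2ccc(-c3cn4ncccc4n3)cc2)no1` gives 59.1 nM
- compound 3 `CC(C)(C)c1cc(NC(=O)Nc2ccc(-c3cn4ccc(Cl)cc4n3)cc2)no1` gives 5.91 nM

Compound 3 gives the lowest number of the three in this assay; compound 1 sits a step higher and compound 2 higher still, both gaps beyond the scatter. Among the measured compounds shown here, the only single-place step among the measured compounds, a 1.3-fold higher number from compound 1 to compound 2 (0.12 log units; within the scatter), swaps one fused bicyclic group for another and lies within the scatter; it says nothing about substitution on the fused ring of compound 3.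

Compound 4 `CCOc1ccn2cc(-c3ccc(NC(=O)Nc4cc(C(C)(C)C)on4)cc3)nc2c1` differs from compound 3 by ethoxy in place of chloro on an aromatic carbon. For the measured compounds named here, no measured step bears on this change: chloro appears only in compound 3, and no ethoxy analogue has been measured. The expectation is therefore loose. Compound 4 is estimated to land close to compound 3, with a step of a 2.0-fold higher number from compound 3 to compound 4 (0.31 log units; beyond the scatter), most likely a modest move toward a higher number and not clearly beyond the scatter. The estimate for compound 4 in this assay is 12 nM, with a range from 3 nM to 50 nM.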

Compound 4, half-maximal inhibitory concentration: 11.6 nM
The estimate for compound 4 lay 1.0-fold (0.01 log units) above the measured number, within the range that was stated.
By their numbers in this assay, from the lowest: compounds 3 and 4 (each within the scatter of the next); then compounds 1 and 2 (each within the scatter of the next).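

In this assay, ethoxy in place of chloro on this aromatic carbon, opposite the ring nitrogen, gives a 2.0-fold higher number from compound 3 to compound 4 (0.29 log units; within the scatter), so the two groups cannot be told apart on this read-out. Among the earlier compounds only compound 3 carried a group at this place, and the pair now shows that its number does not depend on chloro alone: a three-atom group containing oxygen serves here as well as a single chlorine. No measurement shown explains why these two groups read alike.

Still open, from the compounds shown here alone, is how far this position stretches: whether an amine, a carboxylic acid or a longer chain such as butoxy would stay in the same range. Also open is what either group contributes, since the same core with plain hydrogen at this place is not among the compounds shown.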